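A Fluorine Removed: What Compound 3 Might Show

The source may hold more compounds than are shown below. What is called first, only, known or untested is meant among the compounds shown, and "the series" means these compounds.

Measured so far:
compound 1 `CC1(C)CCC(C)(C)c2c1cc(O)c(C(=O)c1ccc3cc(C(=O)O)ccc3c1)c2F`: 46%
compound 2 `COc1c(C(=O)c2ccc3cc(C(=O)O)ccc3c2)ccc2c1C(C)(C)CCC2(C)C`: 0%

In an assay on isolated protein with retinoic acid receptor alpha (Homo sapiens) as the target (on this read-out lower numbers stand for smaller maximal responses and higher numbers for larger maximal responses), compound 1 gives 46%, the highest of the two numbers; compound 2, the only other one, sits lower by a gap that lies beyond the scatter. Compound 3 `CC1(C)CCC(C)(C)c2cc(C(=O)c3ccc4cc(C(=O)O)ccc4c3)c(O)cc21` differs from compound 1 by hydrogen in place of fluoro on an aromatic carbon. Among the compounds with values here, no step between measured compounds isolates this change, so the expectation rests on compound 1 alone. The step of a number 10 percentage points lower from compound 1 to compound 3 (within the scatter) is expected to be small, a modest fall at the edge of the scatter. Compound 3 is expected to reach 36%, somewhere between 12% and 60%.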

Compound 3, largest response reached (reported as maximum), in percent of the reference or control that the assay uses: 44%
Estimate against measurement, compound 3: 8 percentage points below; the measured number falls inside the stated range.
By their numbers in this assay, from the lowest: compound 2; then compounds 3 and 1 (each within the scatter of the next).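

In this assay, within the data shown here, hydrogen in place of fluoro on an aromatic carbon gives a number 2 percentage points lower from compound 1 to compound 3 (within the scatter), the first direct reading of this position. Compound 1 and compound 3 cannot be told apart on this read-out, so the fluoro is not required for the maximal response that the shared core reaches here. No available evidence explains why this position tolerates the change. From the compounds shown here alone, whether a larger group at this position, such as a methyl, a methoxy or an amine, would leave the response equally intact remains open.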